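Trifluoromethyl for methyl in a triazole series

A few compounds are considered here, and "the series" means these few. Any claim that something is new, unique, unknown or untested is made for them only; others in the source may bear on it.

Compound 1 `Cc1ccc(C(O)c2cn(Cc3ccccc3)nn2)cc1` was tested in a functional assay on B16 cells (Mus musculus) for cytotoxicity, read by MTT assay, with a stated time of 48 h; a lower number here means a stronger inhibitor, a higher number a weaker inhibitor. In this assay compound 1 gives only a limit, > 100000 nM. Compound 3 `OC(c1ccc(C(F)(F)F)cc1)c1cn(Cc2ccccc2)nn1` differs from compound 1 in one place: trifluoromethyl in place of methyl on an aromatic carbon. In this assay compound 3 likewise gives a limit, > 100000 nM. The step that the two limits leave unreadable from compound 1 to compound 3 therefore cannot be read. Compound 2 `Cc1ccc(-c2cn(Cc3ccccc3)nn2)cc1` is built on a different core; how the two cores differ is not broken down here. In this assay compound 2 gives a limit, > 100000 nM. All three measured values share the same position, namely (the limit of > 100000 nM in this assay, at which 3 of the 3 values shown sit). Compound 4 `FC(F)(F)c1ccc(-c2cn(Cc3ccccc3)nn2)cc1` has not yet been measured; it differs from compound 2 by trifluoromethyl in place of methyl on an aromatic carbon, the same kind of change that carried compound 1 to compound 3. That earlier change produced nothing readable, and the expectation for the step from compound 2 to compound 4 is accordingly a step that the limit leaves unreadable from compound 2 to compound 4, resting on (the limit of > 100000 nM in this assay, at which 3 of the 3 values shown sit). For compound 4 the estimated value in this assay is 150000 nM, expected to lie between 60000 nM and 400000 nM.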

Compound 4, half-maximal inhibitory concentration: > 100000 nM
Compound 4 gave a limit, no number; the forecaster's own chance of this, stated with the estimate: 85%; the middle value does not contradict the limit.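

In this assay compound 4 gives only a limit, > 100000 nM. Going by these compounds alone, compound 2 also gives only a limit, > 100000 nM, so no step from one to the other can be read. The compounds shown leave open whether trifluoromethyl in place of methyl changes cytotoxicity on either core, as all of them share one position: the limit of > 100000 nM in this assay, at which 4 of the 4 values shown sit.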